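The source may report more compounds than this note shows. Statements on the series, on what has been measured and on what is new or still open speak of the compounds shown alone.

Measured in an in vitro ADME assay on microsomes from liver (Homo sapiens) for metabolic stability; on this read-out lower numbers stand for slow clearance and higher numbers for fast clearance:
compound 1 `COc1ccc(C(=O)N2CCC(=CC(=O)N[C@@H]3CCN(Cc4ccc5cc(F)ccc5c4)C3)CC2)c(O)c1`, 232 mL/min/kg
compound 2 `COc1cccc(C(=O)N2CCC(=CC(=O)N[C@@H]3CCN(Cc4ccc5cc(F)ccc5c4)C3)CC2)c1O`, 162 mL/min/kg
compound 3 `O=C(C=C1CCN(C(=O)c2ccc(F)cc2)CC1)N[C@@H]1CCN(Cc2ccc3cc(F)ccc3c2)C1`, 237 mL/min/kg

Compound 3 sits level with the other two: a 1.0-fold higher number from compound 1 to compound 3 (0.01 log units; within the scatter) and a 1.5-fold higher number from compound 2 to compound 3 (0.17 log units; within the scatter); between the other two the step is a 1.4-fold lower number from compound 1 to compound 2 (0.16 log units; within the scatter). Compound 4 `COc1ccc(O)c(C(=O)N2CCC(=CC(=O)N[C@@H]3CCN(Cc4ccc5cc(F)ccc5c4)C3)CC2)c1` carries 2-hydroxy-5-methoxyphenyl in place of 4-fluorophenyl on a carbonyl carbon. The change runs opposite in direction to the two measured steps onto the same carbonyl carbon, both within the scatter, and compound 1 against compound 2 shows that a different arrangement of hydroxy and methoxy on that ring also stayed within the scatter. No step beyond the scatter is therefore expected in this assay. Compound 4 is expected to give 200 mL/min/kg, estimated between 110 mL/min/kg and 360 mL/min/kg. The expected step is a 1.2-fold lower number from compound 3 to compound 4 (0.07 log units; within the scatter).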

Compound 4, clearance: 119 mL/min/kg
Compound 4: the middle estimate sits 1.7-fold (0.23 log units) above what was measured; the range from low to high includes it.
By their numbers in this assay, from the lowest: compounds 4, 2, 1 and 3 (each within the scatter of the next).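

In this assay the 2-hydroxy-5-methoxyphenyl group gives a 2.0-fold lower number from compound 3 to compound 4 (0.30 log units; within the scatter) so a third arrangement of hydroxy and methoxy also stays within the scatter of the 4-fluorophenyl compound. Against the other two arrangements the reading is the same, with a 1.4-fold lower number from compound 2 to compound 4 (0.13 log units; within the scatter) and a 1.9-fold lower number from compound 1 to compound 4 (0.29 log units; within the scatter) so no arrangement shown on this ring separates from another. No supporting data bear on these numbers. Open, as far as these compounds go, is whether any group on this carbonyl carbon gives a step beyond the scatter, for instance a phenyl carrying an amine or a carboxylic acid.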